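The compounds below may be only part of what the source reports. "The series", "measured", "known", "first", "only" and "open" are said of these compounds alone.

In a physicochemical assay for solubility, read by HPLC, with a stated time of 20 h, at pH 1 (on this read-out lower numbers stand for lower solubility and higher numbers for higher solubility), compound 1 (`O=C(O)C[C@H]1CC[C@H](c2ccc(C(=O)Nc3nnc(Cc4ccc(F)cc4)s3)cc2)CC1`) gives < 2000 nM as a limit, not a number. Compound 2 (`O=C(Nc1nc(Cc2cc(F)cc(F)c2)no1)c1ccc(O[C@H]2CC[C@@H](C(=O)O)CC2)cc1`) gives < 2000 nM as a limit too. Compound 3 (`NC(=O)C[C@H]1CC[C@H](c2ccc(C(=O)Nc3nnc(Cc4ccccc4)s3)cc2)CC1`) likewise gives only a limit of < 2000 nM and so has no exact place on the scale. That leaves one shared reading (the limit of < 2000 nM in this assay, at which 3 of the 3 values shown sit) and no numbers to rank. Compound 4 (`O=C(C[C@H]1CC[C@H](c2ccc(C(=O)Nc3nnc(Cc4ccccc4)s3)cc2)CC1)NCC(O)CO`) carries 2,3-dihydroxypropyl in place of hydrogen on an amide-type nitrogen of compound 3 (2,3-dihydroxypropyl in place of hydrogen on an amide-type nitrogen). Within the data shown here, no measured pair shows what such a change does, so a modest rise in this assay is only an expectation, and another limit is quite possible. The expected step is small (an at least 1.5-fold higher number from compound 3 to compound 4 (0.17 log units; that floor lies within the scatter)). Compound 4 is estimated at 3000 nM within an expected range of 1000 nM to 15000 nM on this read-out.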

Compound 4, solubility: < 2000 nM
Compound 4 gave a limit, no number (the forecaster's own chance of this, stated with the estimate: 55%); at least 1.5-fold (0.17 log units) between middle value and limit.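

Among these compounds, compound 3 and compound 4 each give only a limit in this assay, so no step from one to the other can be read. Still open is where any compound shown truly sits on this scale, since all share one reading: the limit of < 2000 nM in this assay, at which 4 of the 4 values shown sit.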